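The compounds below may be only part of what the source reports. "The series", "measured", "known", "first", "only" and "open" are said of these compounds alone.

Working notes on the coumarin-linked lipoate series in a functional assay on PC-12 cells (Rattus norvegicus) for cytotoxicity, read by MTT assay, with stated times of 3 h and 2 h, tested at 0.1 uM; a lower number here means a weaker effect, a higher number a stronger effect of the compound at the concentration tested.

Compound 1 `CC(=O)c1cc2ccc(OCCCn3cc(CNC(=O)CCCCC4CCSS4)nn3)cc2oc1=O` gives 34.6% in this assay. Compound 2 `O=C(CCCCC1CCSS1)NCc1cn(CCCOc2ccc3cc(-c4ccc(Br)cc4)c(=O)oc3c2)nn1` gives 39.5% in this assay. Compound 3 `O=C(CCCCC1CCSS1)NCc1cn(CCCCOc2ccc3ccc(=O)oc3c2)nn1` gives 40.5% in this assay. Of the three numbers compound 3 stands at the top, but the gaps to compound 2 and to compound 1 both lie within the scatter, so no order among the three can be read from them.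

Compound 4 `O=C(CCCCC1CCSS1)NCc1cn(CCCCOc2ccc3cc(-c4ccc(Br)cc4)c(=O)oc3c2)nn1` has not yet been measured in this assay. It differs from compound 3 by 4-bromophenyl in place of hydrogen on an aromatic carbon. Among the compounds with values here, the one measured step that bears on this change is a number 4.9 percentage points higher from compound 1 to compound 2 (within the scatter): there a 4-bromophenyl entered in place of an acetyl, not in place of a hydrogen, so the match is only partial, and that step stayed within the scatter. Nothing among the three measured compounds points to a step beyond the scatter for the change from compound 3 to compound 4.

Compound 4 is therefore expected to give about 43% in this assay, with a range from 31% to 55%. The expected step of a number 2.5 percentage points higher from compound 3 to compound 4 (within the scatter) is estimated to stay within the scatter.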

Compound 4, a percentage reported as activity, at one concentration (the size of the read-out at that concentration, not a potency): 34.2%
Compound 4: middle estimate off by 8.8 percentage points, on the high side; low and high end bracket the measured number.
By their numbers in this assay, from the lowest: compounds 4, 1, 2 and 3 (each within the scatter of the next).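

In this assay, within the data shown here, the step of a number 6.3 percentage points lower from compound 3 to compound 4 (within the scatter) is the first reading of 4-bromophenyl in place of hydrogen on this aromatic carbon, two atoms from the ring oxygen, and it stays within the scatter despite the addition of a six-membered aromatic ring of 7 heavy atoms. Set beside a number 4.9 percentage points higher from compound 1 to compound 2 (within the scatter), where the same group took the place of an acetyl at this position, it shows two steps of opposite sign, both within the scatter, so neither replacement gives this group a readable direction of effect at the tested concentration. No independent measurement on these compounds is available to account for the result.

As far as these compounds go, whether an amine, a carboxylic acid or a small group such as methyl on this aromatic carbon would produce a step beyond the scatter remains open, as does the outcome of a longer chain between the shared core and the lipoyl amide end. With one read-out at one concentration, the compounds shown also leave open how any of these values would shift at other concentrations.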